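Shifting a Chlorine on a Benzyl Group Against PC-3 Cells

The compounds below may be only part of what the source reports. "The series", "measured", "known", "first", "only" and "open" are said of these compounds alone.

Compound 3 `O=C1/C(=C/c2ccccc2F)CN(C(=S)SCc2cn(Cc3cccc(Cl)c3)nn2)C/C1=C\c1ccccc1F` was tested in a functional assay on PC-3 cells (Homo sapiens) for cytotoxicity, read by MTT assay, with a stated time of 24 h (a higher number here means a weaker inhibitor, a lower number a stronger inhibitor), where compound 3 gives 80000 nM. Compound 1 `O=C1/C(=C/c2ccccc2F)CN(C(=S)SCc2cn(Cc3ccccc3Cl)nn2)C/C1=C\c1ccccc1F` differs from compound 3 in one place (2-chlorophenyl in place of 3-chlorophenyl on a saturated chain carbon bound to an aromatic nitrogen). In this assay compound 1 reaches only the limit > 80000 nM. The step of a number no lower from compound 3 to compound 1 (the limit leaves the size open) cannot be sized because of the limit of > 80000 nM in this assay, at which 2 of the 3 values shown sit.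

Compound 2 `COc1ccc(/C=C2\CN(C(=S)SCc3cn(Cc4cccc(Cl)c4)nn3)C/C(=C\c3ccc(OC)cc3)C2=O)cc1` has a different core from compound 3; how the two cores differ is not broken down here. In this assay compound 2 likewise stops at the limit > 80000 nM. Compound 4 `COc1ccc(/C=C2\CN(C(=S)SCc3cn(Cc4ccccc4Cl)nn3)C/C(=C\c3ccc(OC)cc3)C2=O)cc1` carries the same change relative to compound 2 2-chlorophenyl in place of 3-chlorophenyl on a saturated chain carbon bound to an aromatic nitrogen that compound 1 carries relative to compound 3.

The step that the limit leaves unreadable from compound 2 to compound 4 is expected because the matching step a number no lower from compound 3 to compound 1 (the limit leaves the size open) stayed at the limit. Compound 4 is therefore estimated to give about 120000 nM, with a range from 80000 nM to 300000 nM.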

Compound 4, half-maximal inhibitory concentration: 60100 nM
For compound 4 the middle estimate is 2.0-fold (0.30 log units) above the measured one; the whole stated range lies above it.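

Replacing 3-chlorophenyl with 2-chlorophenyl on a saturated chain carbon bound to an aromatic nitrogen gives an at least 1.3-fold lower number from compound 2 to compound 4 (0.12 log units; that floor lies within the scatter) in this assay. The same change on the other core cannot be sized, so the two steps cannot be set against each other: the same change on two cores in this assay, a number no lower (the limit leaves the size open) from compound 3 to compound 1 and an at least 1.3-fold lower number (0.12 log units; that floor lies within the scatter) from compound 2 to compound 4; the limit leaves it open whether they differ. The series therefore neither shows that the change carries from one core to the other nor shows that it does not, and much of the set rests on a single limit: the limit of > 80000 nM in this assay, at which 2 of the 4 values shown sit.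

Still open, as far as these compounds go, is the size of this step on a core where both partners give numbers rather than limits. Also open, from the compounds shown here alone, is how a benzyl group carrying an amine or a carboxylic acid in place of the chlorine would read in this assay.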